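The compounds below may be only part of what the source reports. "The series", "measured", "known", "first", "only" and "open" are said of these compounds alone.

Working notes on a short series built on one shared core. Among the measured compounds shown here, compound 2 `Fc1cccc(F)c1NCn1nc(-c2ccc3c(c2)OCCO3)oc1=S` gives 3320 nM in a functional assay, with a stated time of 6 min (a higher number here means a weaker inhibitor, a lower number a stronger inhibitor), the lowest of the three numbers measured so far. Compound 1 `Fc1ccc(NCn2nc(-c3ccc4c(c3)OCCO4)oc2=S)cc1` gives 6480 nM in this assay, and compound 3 `S=c1oc(-c2ccc3c(c2)OCCO3)nn1CNc1ccc(Br)cc1Br` gives 6410 nM. The step of a 2.0-fold lower number from compound 1 to compound 2 (0.29 log units; within the scatter) and the step of a 1.9-fold higher number from compound 2 to compound 3 (0.29 log units; within the scatter) both stay within the scatter, as does a 1.0-fold lower number from compound 1 to compound 3 (0.00 log units; within the scatter), so none of the three aryl groups on the amine nitrogen separates from the others in this assay.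

Compound 4 `O=[N+]([O-])c1ccc(NCn2nc(-c3ccc4c(c3)OCCO4)oc2=S)cc1` is not yet measured. It differs from compound 2 in one place: 4-nitrophenyl in place of 2,6-difluorophenyl on an amine nitrogen. The measured steps that bear on this change are those that exchange the aryl group on the amine nitrogen, a 2.0-fold lower number from compound 1 to compound 2 (0.29 log units; within the scatter), a 1.9-fold higher number from compound 2 to compound 3 (0.29 log units; within the scatter) and a 1.0-fold lower number from compound 1 to compound 3 (0.00 log units; within the scatter), and every one of them stayed within the scatter. For the measured compounds named here, the 4-nitrophenyl group is the first on the amine nitrogen to carry hydrogen-bond acceptors, and no measured step reads that feature. The expectation is therefore no step beyond the scatter in this assay, the estimated step from compound 2 being a 1.5-fold higher number from compound 2 to compound 4 (0.18 log units; within the scatter). Compound 4 is estimated at 5000 nM, with a range from 2000 nM to 12000 nM.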

Compound 4, half-maximal inhibitory concentration: 9950 nM
Beside the measured number, compound 4's estimate is 2.0-fold (0.30 log units) below it; the measured number falls inside the stated range.
By their numbers in this assay, from the lowest: compounds 2, 3, 1 and 4 (each within the scatter of the next, the first and the last beyond it).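

In this assay the aryl group on the amine nitrogen now gives its first step beyond the scatter, a modest one: a 3.0-fold higher number from compound 2 to compound 4 (0.48 log units; beyond the scatter) with 4-nitrophenyl in place of 2,6-difluorophenyl, so this position is not wholly indifferent to the exchange. The separation holds for this one pair only, as the exchange from 2,4-dibromophenyl gives a 1.6-fold higher number from compound 3 to compound 4 (0.19 log units; within the scatter) and nitro in place of fluoro on an aromatic carbon gives a 1.5-fold higher number from compound 1 to compound 4 (0.19 log units; within the scatter) and both stay within the scatter, leaving a shallow spread in which only compound 2 and compound 4 part. No supporting measurement bears on this step, so the hydrogen-bond acceptors that enter with 4-nitrophenyl cannot be tied to it.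

The aryl groups shown all carry halogen or nitro substituents, so unsubstituted phenyl, a pyridine ring or a saturated cyclohexyl group on the amine nitrogen remains open. Also open, going by these compounds, is whether the step follows the nitro group or the departure of 2,6-difluorophenyl, a question that a nitrile or a carboxylic acid in place of the nitro group could address.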